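The source may report more compounds than this note shows. Statements on the series, on what has been measured and on what is new or still open speak of the compounds shown alone.

Compound 1 `Cc1[nH]n(-c2nc3cc(-c4ccccc4)ccc3[nH]2)c(=O)c1Cc1ccccc1` — 810 nM
Compound 2 `Cc1[nH]n(-c2nc3ccccc3[nH]2)c(=O)c1CC(=O)O` — 15000 nM
Compound 3 `Cc1cc(O)n(-c2nc3ccccc3[nH]2)n1` — 3600 nM

In an assay on isolated protein for inhibition of alpha-ketoglutarate-dependent dioxygenase alkB homolog 3 (Homo sapiens), read by polymerase chain reaction, with a stated time of 1 h (on this read-out higher numbers stand for weaker inhibition and lower numbers for stronger inhibition), compound 2 stands highest of the three numbers; compound 3 sits beyond the scatter below it, and compound 1 lies furthest below it. Compound 4 `Cc1[nH]n(-c2nc3ccccc3[nH]2)c(=O)c1Cc1ccc(Cl)cc1` differs from compound 2 in one place: 4-chlorophenyl in place of carboxy on a saturated chain carbon bound to an aromatic carbon — cut one bond further out, carboxymethyl gives way to 4-chlorobenzyl. Among the compounds with values here, no measured pair shows exactly this change. Compound 1, which also carries a benzyl group at that chain carbon, gives 810 nM, though it differs from compound 4 elsewhere on the shared core. Compound 4 is therefore expected to show a sizeable drop in number, a 10-fold lower number from compound 2 to compound 4 (1.00 log units; beyond the scatter). The estimate for compound 4 is 1500 nM, within 500 nM to 5000 nM.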

Compound 4, half-maximal inhibitory concentration: > 10000 nM
Compound 4 ended at the assay's limit; the forecaster's own chance of this, stated with the estimate: 5%; middle value at least 6.6-fold (0.82 log units) from the limit.
By their numbers in this assay, from the lowest: compound 1; then compound 3; then compound 2.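

In this assay compound 4 gives > 10000 nM, which is a limit of the assay and not a number, so no step can be read from compound 2 to compound 4. The compounds shown leave open how 4-chlorobenzyl compares with carboxymethyl on this shared core.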